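Fluoro removal on the difluorophenyl side of the stilbene series

The source may report more compounds than this note shows. Statements on the series, on what has been measured and on what is new or still open speak of the compounds shown alone.

Compound 1 `COc1ccc(/C=C/c2ccc(F)cc2)cc1` gives 4200 nM in an assay on HepG2 cells for activation of nuclear factor erythroid 2-related factor 2 (Homo sapiens), read by a luciferase reporter, with a stated time of 5 h; a higher number here means that more compound is needed for the effect, a lower number that less compound is needed. Compound 2 `COc1ccc(/C=C/c2ccc(F)c(F)c2)cc1` reaches only the limit of this assay, > 15000 nM. Compound 3 `Fc1cccc(/C=C/c2ccc(F)c(F)c2)c1` gives 5000 nM in this assay; the difference between the cores of compound 3 and compound 2 is not broken down here, and compound 3 and compound 1 lie within the scatter of each other. The step of an at least 3.5-fold lower number from compound 2 to compound 1 (0.55 log units; beyond the scatter) is hydrogen in place of fluoro on an aromatic carbon; its size is known only as a lower bound because of the limit of > 15000 nM in this assay, at which 1 of the 3 values shown sits. Compound 4 `Fc1cccc(/C=C/c2cccc(F)c2)c1` is not yet measured; it differs from compound 3 by hydrogen in place of fluoro on an aromatic carbon, the same kind of change, though here the carbon is para to a group of 9 heavy atoms rather than meta to a large group. In this assay the step of a 2.8-fold lower number from compound 3 to compound 4 (0.44 log units; beyond the scatter) is expected, resting on the step of an at least 3.5-fold lower number from compound 2 to compound 1 (0.55 log units; beyond the scatter). Compound 4 is estimated at 1800 nM, with a range from 600 nM to 6000 nM.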

Compound 4, half-maximal effective concentration: 1000 nM
Compound 4: the middle estimate sits 1.8-fold (0.26 log units) above what was measured; the range from low to high includes it.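

Hydrogen in place of fluoro on an aromatic carbon lowers the number on both cores in this assay, and on the second core the size can be read in full: a 5.0-fold lower number from compound 3 to compound 4 (0.70 log units; beyond the scatter). The direction of the change therefore carries from one core to the other in these two pairs, but equal size is not shown: the same change on two cores in this assay, an at least 3.5-fold lower number (0.55 log units; beyond the scatter) from compound 2 to compound 1 and a 5.0-fold lower number (0.70 log units; beyond the scatter) from compound 3 to compound 4; the limit leaves it open whether they differ One side of the earlier step is a limit and not a number: the limit of > 15000 nM in this assay, at which 1 of the 4 values shown sits.

The compounds shown leave open whether the change acts the same way on any further core. They also leave open how a chloro group, a nitrile or an amine on that aromatic carbon would compare with fluoro and hydrogen.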